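This account rests on a few compounds, and the source may have more. Where it says the series, first, only, none or still open, it means among the compounds named here.

Four compounds share a common core and differ only in small details around it; the question is how strongly each one acts in a functional assay on the whole organism for antagonist activity, with Mus musculus as the target; on this read-out higher numbers stand for an effect only at larger amounts of compound and lower numbers for an effect already at smaller amounts. Compound 1, `COC(=O)N(C)C(C)C#CCn1ccnc1`, reaches only the limit of > 100 mg/kg in this assay, so for it a limit and not a number is known. Compound 2, `COC(=O)N(C)C(C)C#CCn1cncc1C`, gives 6.6 mg/kg in this assay. The two structures differ in a single place, (methyl in place of hydrogen on an aromatic carbon), and this change made a large step: an at least 15-fold lower number from compound 1 to compound 2 (1.18 log units; beyond the scatter). The size of that step rests on (the limit of > 100 mg/kg in this assay, at which 1 of the 3 values shown sits), so it is known only as a lower bound. Compound 3, `CCOC(=O)N(C)CC#CCn1ccnc1`, gives 97 mg/kg in this assay; how its core differs from the core of compound 1 is not broken down here. Compound 4, `CCOC(=O)N(C)CC#CCn1cncc1C`, has not yet been measured in this assay. It stands to compound 3 exactly as compound 2 stands to compound 1, with the same change in the same place: methyl in place of hydrogen on an aromatic carbon. On the strength of the measured step from compound 1 to compound 2, a step of similar size is expected here, a 12-fold lower number from compound 3 to compound 4 (1.08 log units; beyond the scatter). Accordingly, compound 4 is expected to give about 8 mg/kg in this assay, with a likely range from 3 mg/kg to 30 mg/kg, the uncertainty reflecting that only one earlier example of this change is at hand.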

Compound 4, dose for half-maximal effect: 66 mg/kg
The estimate for compound 4 lay 8.3-fold (0.92 log units) below the measured number; measured number outside the range, above it.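

On the core of compound 3, methyl in place of hydrogen on an aromatic carbon gives a 1.5-fold lower number from compound 3 to compound 4 (0.17 log units; within the scatter) in this assay, so on this core the read-out does not separate the methyl compound from the hydrogen compound. The large effect seen on the first core therefore does not carry over at the same size, which shows that in this series one step on one core is a poor guide to the same step on another, although two pairs cannot show which difference between the cores is responsible: the same change on two cores in this assay, an at least 15-fold lower number (1.18 log units; beyond the scatter) from compound 1 to compound 2 and a 1.5-fold lower number (0.17 log units; within the scatter) from compound 3 to compound 4, at least 10-fold (1.01 log units) apart, beyond the scatter of two such steps

The earlier step is also only a lower bound, as compound 1 has a limit and not a number, so the true gap between the two steps could be wider than printed: the limit of > 100 mg/kg in this assay, at which 1 of the 4 values shown sits.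

The compounds shown leave open which detail of the two cores decides the size of the step, and a core changed in one detail only would be needed to separate those details. Also open, going by these compounds, is how a longer chain or an amine on that same aromatic carbon would behave on each core, and whether either would give a step beyond the scatter.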